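Working notes: the step from compound 2 to compound 3

The source may hold more compounds than are shown below. What is called first, only, known or untested is meant among the compounds shown, and "the series" means these compounds.

Compound 2 `COCc1cc(-c2noc([C@H](C)NC(=O)c3cc(C(F)(F)F)nn3C)n2)ccn1` gives 200000 nM in a physicochemical assay for solubility, measured as kinetic solubility (a higher number here means a more soluble compound, a lower number a less soluble compound), the higher of the two numbers shown, though compound 1 `COc1cc(-c2noc([C@H](C)NC(=O)c3cc(C(F)(F)F)nn3C)n2)ccn1` with 156000 nM lies within the scatter of it, as the step of a 1.3-fold higher number from compound 1 to compound 2 (0.11 log units; within the scatter) records. Compound 3 `C[C@H](NC(=O)c1cc(C(F)(F)F)nn1C)c1nc(-c2ccnc(C(F)(F)F)c2)no1` is not yet measured. It differs from compound 2 by trifluoromethyl in place of methoxymethyl on an aromatic carbon. Going by the values given here, no measured step covers this change: the one step on hand, a 1.3-fold higher number from compound 1 to compound 2 (0.11 log units; within the scatter), exchanges methoxy for methoxymethyl and keeps a hydrogen-bond acceptor, so it bears on compound 3 only loosely. The expectation for compound 3 therefore rests on the change itself, in which the hydrogen-bond acceptor counted for methoxymethyl leaves and trifluoromethyl, with none, enters; a lower number in this assay is expected, a 3.3-fold lower number from compound 2 to compound 3 (0.52 log units; beyond the scatter). Compound 3 is estimated at 60000 nM, with a range of 20000 nM to 160000 nM.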

Compound 3, solubility: 58000 nM
Compound 3: the middle estimate sits 1.0-fold (0.01 log units) above what was measured; measured number inside the range.
By their numbers in this assay, from the lowest: compound 3; then compounds 1 and 2 (each within the scatter of the next).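

In this assay, the aromatic carbon next to the ring nitrogen now shows steps beyond the scatter: trifluoromethyl in place of methoxymethyl gives a 3.4-fold lower number from compound 2 to compound 3 (0.54 log units; beyond the scatter), and trifluoromethyl in place of methoxy gives a 2.7-fold lower number from compound 1 to compound 3 (0.43 log units; beyond the scatter). Compound 1 and compound 2 lay within the scatter of each other, whereas trifluoromethyl, which counts no hydrogen-bond acceptor, shows that this position does not tolerate every change without a shift, though both steps are modest. Nothing available explains the lower number.

Going by these compounds alone, with only three groups at this carbon, the loss of the hydrogen-bond acceptor cannot be separated from the other differences between them. From the compounds shown here alone, a plain methyl, an amine or a carboxylic acid at this carbon would bear on that, and whether the same exchange elsewhere on the shared core gives a similar step remains open.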